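Swapping a formyl for an ethynyl on a bicyclic core

This account rests on a few compounds, and the source may have more. Where it says the series, first, only, none or still open, it means among the compounds named here.

Measured so far in a functional assay on B16 cells (Mus musculus) for cytotoxicity, read by MTT assay, with a stated time of 48 h; on this read-out higher numbers stand for weaker inhibition and lower numbers for stronger inhibition:
compound 1, `C=C1CC[C@@H](C(C)C)[C@]12CC=C(C=O)CC2`, gives 428000 nM;
compound 2, `CC1(C)CCCC2=CC=C(C=O)CC[C@]21C`, gives 145000 nM;
compound 3, `C#CC1=CC[C@@]2(C)C(=C)CCC[C@]2(C)CC1`, gives 507000 nM.

Compound 1 stands second highest of the three numbers. Its nearest neighbour is compound 3, whose number lies higher by an amount within the usual scatter, so the two cannot be told apart on this read-out. Compound 2 lies lower by an amount beyond the scatter, so compound 2 inhibits more strongly than compound 1.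

Compound 4, `C#CC1=CC[C@]2(CC1)C(=C)CC[C@H]2C(C)C`, has not yet been measured. It differs from compound 1 in one place: ethynyl in place of formyl on a double-bonded ring carbon. The rest of the core of compound 1 is kept.

For the measured compounds named here, no pair of measured compounds differs in just one place, so the size of this step cannot be read off directly. Going by the values given here, the only hint comes from compound 3, which also carries an ethynyl and gives 507000 nM, a number close to that of compound 1. On that basis the step from compound 1 to compound 4 is expected to be small, a 1.2-fold higher number from compound 1 to compound 4 (0.07 log units; within the scatter), not beyond the scatter. Compound 4 is expected to give about 500000 nM, within a range from 250000 nM to 1000000 nM.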

Compound 4, half-maximal inhibitory concentration: 123000 nM
Beside the measured number, compound 4's estimate is 4.1-fold (0.61 log units) above it; the measured number lies below the stated range.
By their numbers in this assay, from the lowest: compounds 4 and 2 (each within the scatter of the next); then compounds 1 and 3 (each within the scatter of the next).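

In this assay, the core of compound 1 now gives a step that can be read directly at this double-bonded ring carbon: ethynyl in place of formyl gives a 3.5-fold lower number from compound 1 to compound 4 (0.54 log units; beyond the scatter), so compound 4 inhibits more strongly than compound 1. The formyl counts one hydrogen-bond acceptor and the ethynyl none, so on this core a hydrogen-bond acceptor at this carbon is not required for the inhibition seen here. Nothing available here explains why this change lowers the number.

On these data alone, this is a single step on a single core, so it remains open whether ethynyl in place of formyl would also lower the number on the core of compound 2, which carries a formyl of its own. As far as these compounds go, it also remains open how other groups on the same ring carbon, such as a carboxylic acid, an amine or a nitrile, would compare with the ethynyl of compound 4 on the shared core.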